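This account rests on a few compounds, and the source may have more. Where it says the series, first, only, none or still open, it means among the compounds named here.

In a functional assay on L1210 cells (Mus musculus) for cytotoxicity, with a stated time of 48 h (on this read-out higher numbers stand for weaker inhibition and lower numbers for stronger inhibition), compound 2 `Clc1ccc(Cc2nn3cc(-c4ccc(Br)cc4)nc3s2)cc1` gives > 250000 nM, which is a limit of the assay rather than a number. Compound 1 `Clc1ccc(-c2cn3nc(Cl)sc3n2)cc1` likewise gives > 250000 nM in this assay, again a limit. the limit of > 250000 nM in this assay, at which 2 of the 2 values shown sit, shows where both measured values sit. Compound 3 `Clc1ccc(Cc2nn3cc(-c4ccc(Cl)cc4Cl)nc3s2)cc1` differs from compound 2 in one place: 2,4-dichlorophenyl in place of 4-bromophenyl on an aromatic carbon. Among the measured compounds shown here, no step between measured compounds exists to gauge this change, so no shift beyond the usual scatter is expected. The expected step is a number no higher from compound 2 to compound 3 (the limit leaves the size open). Compound 3 is expected to give 250000 nM in this assay, within a range from 100000 nM to 1000000 nM.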

Compound 3, half-maximal inhibitory concentration: 247000 nM
Compound 3: the middle estimate sits 1.0-fold (0.01 log units) above what was measured; the measured number falls inside the stated range.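

In this assay, 2,4-dichlorophenyl in place of 4-bromophenyl on this aromatic carbon gives an at least 1.0-fold lower number from compound 2 to compound 3 (0.00 log units; that floor lies within the scatter). Among the compounds shown here, compound 3 thus gives the first true number, yet this step cannot show a real gain in cytotoxicity. The values still cluster at the edge of what the assay can read: the limit of > 250000 nM in this assay, at which 2 of the 3 values shown sit.

Going by these compounds, what an amine or a carboxylic acid on this phenyl ring would do stays open. So does whether any group at this position can move the number clearly beyond the usual scatter.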